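Toward compound 4: free hydroxy on the aryl group

The source may hold more compounds than are shown below. What is called first, only, known or untested is meant among the compounds shown, and "the series" means these compounds.

Measured in an ADME assay on HEp-2 cells (Homo sapiens) for cytotoxicity, read by MTT assay, with a stated time of 72 h; a lower number here means a stronger inhibitor, a higher number a weaker inhibitor:
- Compound 1 `COc1ccc(C2=C(c3cc(OC)c(OC)c(OC)c3)C(=O)CC2O[SiH2]C(C)(C)C)cc1`: > 100 ug/mL, a limit of the assay
- Compound 2 `COCOc1cc(C2=C(c3cc(OC)c(OC)c(OC)c3)C(=O)CC2O[SiH2]C(C)(C)C)ccc1OC`: 12 ug/mL
- Compound 3 `COc1cc(C2=C(c3cc(C)c(OC)c(C)c3)C(O[SiH2]C(C)(C)C)CC2=O)cc(OC)c1OC`: 26 ug/mL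

Compound 3 holds the higher of the two true numbers in this assay. Compound 4 `COc1ccc(C2=C(c3cc(OC)c(OC)c(OC)c3)C(=O)CC2O[SiH2]C(C)(C)C)cc1O` differs from compound 3 by 3-hydroxy-4-methoxyphenyl in place of 4-methoxy-3,5-dimethylphenyl on a double-bonded ring carbon. The nearest guide is a 2.2-fold higher number from compound 2 to compound 3 (0.34 log units; beyond the scatter), since compound 2 also carries an oxygen substituent on the aryl group. an at least 8.3-fold lower number from compound 1 to compound 2 (0.92 log units; beyond the scatter) and an at least 3.8-fold lower number from compound 1 to compound 3 (0.58 log units; beyond the scatter) also bear on the change, though both start from a limit. A modest move to a lower number is therefore expected, with the estimated step of a 3.3-fold lower number from compound 3 to compound 4 (0.51 log units; beyond the scatter). For compound 4 the expected value is 8 ug/mL, with an estimated range of 1.5 ug/mL to 35 ug/mL.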

Compound 4, half-maximal inhibitory concentration: 14.5 ug/mL
Compound 4: the middle estimate sits 1.8-fold (0.26 log units) below what was measured; low and high end bracket the measured number.
By their numbers in this assay, from the lowest: compounds 2, 4 and 3 (each within the scatter of the next, the first and the last beyond it). At a limit, above all of these: compound 1.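

In this assay, hydrogen in place of methoxymethyl on the aryl oxygen gives a 1.2-fold higher number from compound 2 to compound 4 (0.08 log units; within the scatter), so the free hydroxy and the methoxymethoxy group cannot be told apart here. The swap of 4-methoxy-3,5-dimethylphenyl for 3-hydroxy-4-methoxyphenyl is equally unresolved, with a 1.8-fold lower number from compound 3 to compound 4 (0.25 log units; within the scatter). Hydroxy in place of hydrogen on the aromatic carbon gives an at least 6.8-fold lower number from compound 1 to compound 4 (0.83 log units; beyond the scatter), a bound rather than a measured size, set by a limit: the limit of > 100 ug/mL in this assay, at which 1 of the 4 values shown sits.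

Open, from the compounds shown here alone, is how an amine or a carboxylic acid would read at this aromatic carbon. Also open, going by these compounds, is how a longer chain on the oxygen would read.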